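Fluoro to Methyl on the Carboxyphenyl Ring

This account rests on a few compounds, and the source may have more. Where it says the series, first, only, none or still open, it means among the compounds named here.

Measured so far:
compound 1, `Cc1c(OCCCCOc2ccccc2C(=O)O)ccc(C(=O)CC(C)C)c1O`: 28.1%
compound 2, `CCCC(=O)c1ccc(OCCCCOc2ccc(C(=O)O)cc2C)c(C)c1O`: 40.5%
compound 3, `Cc1c(OCCCCOc2ccc(C(=O)O)cc2F)ccc(C(=O)CC(C)C)c1O`: 67.7%

In an assay on HEK293 cells for positive allosteric modulation of metabotropic glutamate receptor 3 (Rattus norvegicus), read by thallium flux, with a stated time of 2.5 min (a lower number here means a smaller maximal response, a higher number a larger maximal response), compound 3 gives 67.7%, the highest of the three numbers, with compound 2 nearest at 40.5% and compound 1 furthest at 28.1%; both gaps lie beyond the scatter. For the measured compounds named here, the one single-point step measured, a number 39.6 percentage points higher from compound 1 to compound 3 (beyond the scatter), concerns a change of the carboxyphenyl group as a whole and is large.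

Compound 4, `Cc1cc(C(=O)O)ccc1OCCCCOc1ccc(C(=O)CC(C)C)c(O)c1C`, is not yet measured. It differs from compound 3 by methyl in place of fluoro on an aromatic carbon. Going by the values given here, no measured step bears directly on this exchange: the step from compound 1 to compound 3 changes a different part of the same ring, and compound 2, which carries the same 4-carboxy-2-methylphenyl group but a shorter acyl chain, has no measured partner that differs from it in one place. That compound 2 sits well below compound 3 hints that the methyl-bearing ring may not reach the highest response, yet the acyl difference clouds that reading.

Compound 4 is therefore expected to show a modest decrease, a number 12.7 percentage points lower from compound 3 to compound 4 (beyond the scatter), at the edge of the scatter. The estimate for compound 4 is 55%, with a range from 35% to 75%.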

Compound 4, largest response reached (reported as percent of maximum), in percent of the reference or control that the assay uses: 42.1%
Beside the measured number, compound 4's estimate is 12.9 percentage points above it, within the range that was stated.
By their numbers in this assay, from the lowest: compound 1; then compounds 2 and 4 (each within the scatter of the next); then compound 3.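

In this assay the aromatic carbon ortho to a large group and meta to a carboxy group proves sensitive, since with everything else in the molecule unchanged, exchanging fluoro for methyl there costs much of the response (a number 25.6 percentage points lower from compound 3 to compound 4 (beyond the scatter)). The change in the acyl chain, by contrast, a methyl in place of hydrogen on a saturated chain carbon bound to two saturated chain carbons, does not register (a number 1.6 percentage points higher from compound 2 to compound 4 (within the scatter)), so the acyl difference that clouded the reading of compound 2 turns out to matter little in the methyl-bearing series. The 4-carboxy-2-methylphenyl group still gives more than the 2-carboxyphenyl group (a number 14 percentage points higher from compound 1 to compound 4 (beyond the scatter)), but this gain is smaller than the one brought by the 4-carboxy-2-fluorophenyl group (a number 39.6 percentage points higher from compound 1 to compound 3 (beyond the scatter)).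

Nothing given here explains why fluoro and methyl part so clearly at this position. The compounds shown also leave open how a chloro, a methoxy or a bare hydrogen on this carbon would compare with fluoro and methyl, and whether the fluoro-bearing compound 3 would tolerate the shorter acyl chain as well as the methyl-bearing ring does.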